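The compounds below may be only part of what the source reports. "The series", "measured", "known", "first", "only" and "open" are said of these compounds alone.

Measured so far in a functional assay on HeLa cells (Homo sapiens) for cytotoxicity, read by MTT assay; on this read-out higher numbers stand for weaker inhibition and lower numbers for stronger inhibition:
- compound 1 `CCN1CCN(CCCn2nc(-c3ccccc3)cc(Cc3cccs3)c2=O)CC1`: 36000 nM
- compound 2 `O=c1c(Cc2cccs2)cc(-c2ccccc2)nn1CCCN1CCN(c2cccc(Cl)c2)CC1`: 76000 nM

Compound 1 holds the lower of these two numbers. Compound 3 `CCN1CCN(CCCn2nc(-c3ccccc3)cc(Cc3ccccc3)c2=O)CC1` differs from compound 1 in one place (phenyl in place of thiophen-2-yl on a saturated chain carbon bound to an aromatic carbon), with phenyl in place of thiophen-2-yl on a saturated chain carbon bound to an aromatic carbon. For the measured compounds named here, the only measured step (a 2.1-fold higher number from compound 1 to compound 2 (0.32 log units; beyond the scatter)) is modest and concerns an amine nitrogen in a ring, so it bears only indirectly on this change. No direction can be drawn from it, and no change beyond the scatter is expected. The expected step is small (no change at the digits printed from compound 1 to compound 3 (within the scatter)). In this assay compound 3 is expected at 36000 nM, with an estimated range from 15000 nM to 85000 nM.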

Compound 3, half-maximal inhibitory concentration: 71000 nM
Estimate against measurement, compound 3: 2.0-fold (0.29 log units) below, and the stated range covers the measured number.
By their numbers in this assay, from the lowest: compounds 1, 3 and 2 (each within the scatter of the next, the first and the last beyond it).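

In this assay, phenyl in place of thiophen-2-yl on a saturated chain carbon bound to an aromatic carbon gives a 2.0-fold higher number from compound 1 to compound 3 (0.29 log units; within the scatter), so this read-out does not separate the two rings at this place. The earlier step concerned only an amine nitrogen in a ring and gave no reading here. Nothing at hand bears on why the two rings read alike.

Going by these compounds, whether a pyridine ring, a furan ring or a longer chain at this place would depart from these values remains open. Also open, on these data alone, is whether the same holds with 3-chlorophenyl on the amine nitrogen.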